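This account rests on a few compounds, and the source may have more. Where it says the series, first, only, none or still open, it means among the compounds named here.

Compound 1 `Oc1ccc(-c2cc(-c3ccccc3F)cc(-c3cccc(O)c3)n2)cc1` and compound 2 `Oc1ccc(-c2cc(-c3ccccc3F)cc(-c3ccc(O)cc3)n2)cc1` share a core and differ only by 4-hydroxyphenyl in place of 3-hydroxyphenyl on an aromatic carbon. In a functional assay on HeLa cells (Homo sapiens) for inhibition (a higher number here means a weaker inhibitor, a lower number a stronger inhibitor), compound 1 gives 14300 nM. In this assay compound 2 gives only a limit, > 50000 nM. The step of an at least 3.4-fold higher number from compound 1 to compound 2 (0.54 log units; beyond the scatter) is therefore open-ended because compound 2 sits at the limit of > 50000 nM in this assay, at which 1 of the 3 values shown sits. Compound 3 `Oc1cccc(-c2cc(-c3cccc(OC(F)(F)F)c3)cc(-c3ccccc3O)n2)c1` carries a different core, and the difference between the two cores is not broken down here; in this assay compound 3 gives 14900 nM. Compound 4 `Oc1ccc(-c2cc(-c3cccc(OC(F)(F)F)c3)cc(-c3ccccc3O)n2)cc1` relates to compound 3 by 4-hydroxyphenyl in place of 3-hydroxyphenyl on an aromatic carbon, the same kind of change, though here the site is meta to a 2-hydroxyphenyl group and meta to a large group rather than meta to a 2-fluorophenyl group and a 4-hydroxyphenyl group. Resting on compound 1 and an at least 3.4-fold higher number from compound 1 to compound 2 (0.54 log units; beyond the scatter), compound 4 is expected to show a step of a 3.0-fold higher number from compound 3 to compound 4 (0.48 log units; beyond the scatter), landing near 45000 nM.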

Compound 4, half-maximal inhibitory concentration: > 50000 nM
Compound 4: only a limit was reported; the forecaster's own chance of this, stated with the estimate: 50%; middle value at least 1.1-fold (0.04 log units) away from the limit.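

On the core of compound 3, 4-hydroxyphenyl in place of 3-hydroxyphenyl gives an at least 3.3-fold higher number from compound 3 to compound 4 (0.52 log units; beyond the scatter) in this assay, so the direction seen on the core of compound 1 carries over in these two pairs: the same change on two cores in this assay, an at least 3.4-fold higher number (0.54 log units; beyond the scatter) from compound 1 to compound 2 and an at least 3.3-fold higher number (0.52 log units; beyond the scatter) from compound 3 to compound 4; the limit leaves it open whether they differ

What this does not show is how large either step really is, or whether the two sizes match, because both 4-hydroxyphenyl compounds give only a limit: the limit of > 50000 nM in this assay, at which 2 of the 4 values shown sit.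

The compounds shown leave open whether the same change holds on cores beyond these two. They also leave open how an amine or a methoxy group in place of the hydroxyl on this phenyl ring would read out in this assay.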